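Notes on the sulfur-free chain variant, compound 4

This account rests on a few compounds, and the source may have more. Where it says the series, first, only, none or still open, it means among the compounds named here.

Compound 1 `O=S1(=O)CCC(CNCCCCN(C[C@H]2Cc3ccccc3CN2)[C@H]2CCCc3cccnc32)CC1` is the reference. Among the measured compounds shown here, in a functional assay on cells for antagonist activity at C-X-C chemokine receptor type 4 (Homo sapiens), read by fluorescence and calcium flux, with stated times of 25 min and 90 s (a lower number here means a stronger inhibitor, a higher number a weaker inhibitor), compound 1 gives 17 nM, the lowest of the three numbers measured so far. Compound 3 `FC1(F)CCC(NCc2ccc(CN(C[C@H]3Cc4ccccc4CN3)[C@H]3CCCc4cccnc43)cc2)CC1` gives 143 nM in this assay, and compound 2 `NCc1cccc(CN(C[C@H]2Cc3ccccc3CN2)[C@H]2CCCc3cccnc32)c1` gives 292 nM; both gaps to compound 1 lie beyond the scatter, so compound 1 stands clearly ahead of the two measured neighbours. For the measured compounds named here, neither of these two differs from compound 1 in a single place, so no step between measured compounds is available to calibrate the change at hand.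

Compound 4 `CC(C)(CCN(C[C@H]1Cc2ccccc2CN1)[C@H]1CCCc2cccnc21)CNC1CCOCC1` is not yet measured. Relative to compound 1 the change is a group of 11 heavy atoms (9 carbon, 1 nitrogen, 1 oxygen; one six-membered non-aromatic ring with 1 hetero atom) in place of a group of 12 heavy atoms (8 carbon, 1 nitrogen, 2 oxygen, 1 sulfur; one six-membered non-aromatic ring with 1 hetero atom), on a saturated chain carbon, two bonds along the chain from an amine nitrogen. The group that leaves carries two oxygen atoms and a sulfur atom; the group that enters carries one oxygen atom, and the hydrogen-bond donor count is kept while one acceptor is lost. Going by the values given here, with no measured single-point step to lean on, the expectation for this assay is a modest move toward a higher number, close to the edge of the scatter, with the step of a 2.1-fold higher number from compound 1 to compound 4 (0.31 log units; beyond the scatter) expected. Compound 4 is therefore estimated at 35 nM in this assay, within a range of 10 nM to 120 nM.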

Compound 4, half-maximal inhibitory concentration: 36.3 nM
Compound 4: middle estimate off by 1.0-fold (0.02 log units), on the low side; the range from low to high includes it.
By their numbers in this assay, from the lowest: compound 1; then compound 4; then compound 3; then compound 2.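

With the measurement of compound 4, the series has its first single-place step in this assay: a 2.1-fold higher number from compound 1 to compound 4 (0.33 log units; beyond the scatter), modest in size. It shows that on a saturated chain carbon, two bonds along the chain from an amine nitrogen, the group of 12 heavy atoms, with its sulfur atom and two oxygen atoms, can give way to the group of 11 heavy atoms, with one oxygen atom and no sulfur, at a small but real cost in this assay; the sulfur atom and the second oxygen atom are therefore not required for inhibition in the tested compounds. No measurement bears on why the number moves by this amount.

The step exchanges the whole group at once, so the shares of the sulfur atom, the lost acceptor and the remaining differences between the two groups cannot be told apart. Also open, from the compounds shown here alone, is how this place would respond to a group of another kind, such as a carboxylic acid or a longer chain carrying a second amine.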